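Adding a second 4-cyanobenzyl to the amine of compound 2

The source may report more compounds than this note shows. Statements on the series, on what has been measured and on what is new or still open speak of the compounds shown alone.

Compound 2 `N#Cc1ccc(CN[C@@H]2CN[C@H](C(=O)N3CCSC3)C2)cc1` gives 34.3 nM in an assay on a cell-free system (plasma) for inhibition of Dipeptidyl peptidase 4 (Rattus norvegicus), read by fluorescence; a higher number here means a weaker inhibitor, a lower number a stronger inhibitor. It stands second highest of the three measured numbers: compound 3 `N#Cc1ccc(C(=O)N[C@@H]2CN[C@H](C(=O)N3CCSC3)C2)cc1` gives 34.1 nM, which lies within the scatter of compound 2, while compound 1 `O=C([C@@H]1C[C@H](NCc2ccccc2)CN1)N1CCSC1` gives 171 nM. Within the data shown here, the only single-point step, a 5.0-fold lower number from compound 1 to compound 2 (0.70 log units; beyond the scatter), concerns the cyano on the aromatic carbon and not the amine nitrogen. Compound 4 `N#Cc1ccc(CN(Cc2ccc(C#N)cc2)[C@@H]2CN[C@H](C(=O)N3CCSC3)C2)cc1` differs from compound 2 by 4-cyanobenzyl in place of hydrogen on an amine nitrogen, on an amine nitrogen whose other neighbours are a saturated chain carbon and a saturated ring carbon. Among the measured compounds shown here, no measured step touches this nitrogen directly; compound 2 and compound 3 together show only that the amine hydrogen against an amide hydrogen leaves the number unchanged. In this assay the step from compound 2 to compound 4 is therefore expected to be small, most likely a modestly higher number, a 2.6-fold higher number from compound 2 to compound 4 (0.42 log units; beyond the scatter). Compound 4 is estimated at 90 nM, with a range from 25 nM to 350 nM.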

Compound 4, half-maximal inhibitory concentration: 9.3 nM
Compound 4: middle estimate off by 9.7-fold (0.99 log units), on the high side; the measured number lies below the stated range.
By their numbers in this assay, from the lowest: compound 4; then compounds 3 and 2 (each within the scatter of the next); then compound 1.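

In this assay, among these compounds, the amine nitrogen, which no earlier step had touched, takes a second 4-cyanobenzyl with a 3.7-fold lower number from compound 2 to compound 4 (0.57 log units; beyond the scatter) and does not need its hydrogen for this read-out. Among the compounds shown here, the earlier compounds had tested a change only on the aromatic carbon, so this is the first sign that a substituent of 9 heavy atoms on this nitrogen goes with a lower number rather than a higher one. Nothing given here bears on why the number falls.

The compounds shown leave open whether the step belongs to the added aromatic ring or to its nitrile, as the 4-cyanobenzyl brings both at once. A plain benzyl on the same nitrogen would separate the two, and a methyl would show whether a much smaller group on this nitrogen moves the number at all.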